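From 2-fluorophenyl to 4-nitrophenyl on the shared core

The source may hold more compounds than are shown below. What is called first, only, known or untested is meant among the compounds shown, and "the series" means these compounds.

Among the measured compounds shown here, in a functional assay on HepG2 cells (Homo sapiens) for antiproliferative activity, read by MTT assay, with a stated time of 48 h (on this read-out higher numbers stand for weaker inhibition and lower numbers for stronger inhibition), compound 1 `CC(=O)N1N=C(c2ccc3ccccc3c2)OC1c1ccccc1Cl` gives 4.32 ug/mL and compound 2 `CC(=O)N1N=C(c2ccc3ccccc3c2)OC1c1ccccc1F` gives 3.36 ug/mL as the only two numbers so far, and they lie within the scatter of each other. For the measured compounds named here, the one measured step is a 1.3-fold lower number from compound 1 to compound 2 (0.11 log units; within the scatter) and consists of fluoro in place of chloro on an aromatic carbon. Compound 3 `CC(=O)N1N=C(c2ccc3ccccc3c2)OC1c1ccc([N+](=O)[O-])cc1` is still unmeasured and differs from compound 2 at a single place (4-nitrophenyl in place of 2-fluorophenyl on a saturated ring carbon), with 4-nitrophenyl in place of 2-fluorophenyl on a saturated ring carbon next to the ring oxygen. Going by the values given here, only that one measured step bears on this change, and it is a weak guide: it exchanged chloro for fluoro, and no measured compound carries 4-nitrophenyl. As far as these compounds go, with that step within the scatter, no step beyond the scatter is expected in this assay and the direction stays open. The estimated change is a 1.2-fold higher number from compound 2 to compound 3 (0.06 log units; within the scatter) and counts as small. The estimate for compound 3 is 3.9 ug/mL with a deliberately wide range of 1.5 ug/mL to 10 ug/mL as the expected bounds of repeated measurements.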

Compound 3, half-maximal inhibitory concentration: 8.1 ug/mL
Compound 3: the middle estimate sits 2.1-fold (0.32 log units) below what was measured; measured number inside the range.
By their numbers in this assay, from the lowest: compounds 2, 1 and 3 (each within the scatter of the next, the first and the last beyond it).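

Among the compounds shown here, at this position, replacing a halogen-bearing phenyl with 4-nitrophenyl produces the first step beyond the scatter in this assay: there is a 2.4-fold higher number from compound 2 to compound 3 (0.38 log units; beyond the scatter). Starting from 2-chlorophenyl instead, the change gives a 1.9-fold higher number from compound 1 to compound 3 (0.27 log units; within the scatter), so the group on this saturated ring carbon can shift the number by a measurable margin, but here that margin appears against only one of the two halogen-bearing compounds. Nothing available explains why the number moves with this exchange.

4-nitrophenyl differs from 2-fluorophenyl both in the group it carries and in where that group sits on the phenyl ring, and the compounds shown do not separate these two differences. They also leave open how this position would read with an amine or a carboxylic acid on the phenyl ring in this assay, or with a plain phenyl carrying no group at all.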